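Enone reversal on the fused core: compound 3 to compound 4

A few compounds are considered here, and "the series" means these few. Any claim that something is new, unique, unknown or untested is made for them only; others in the source may bear on it.

Compound 3 `COc1ccc(-c2cc(C(=O)/C=C/c3ccc(C)cc3)nc3cc(-c4ccccc4)nn23)cc1OC` gives 22600 nM in a functional assay on MDA-MB-231 cells (Homo sapiens) for antiproliferative activity, read by MTT assay, with a stated time of 24 h (on this read-out higher numbers stand for weaker inhibition and lower numbers for stronger inhibition), the highest of the three numbers measured. Compound 2 `COc1ccc(/C=C/C(=O)c2cc(-c3ccc(OC)c(OC)c3)n3nc(-c4ccccc4)cc3n2)cc1` gives 22000 nM in this assay, within the scatter of compound 3; compound 1 `COc1ccc(-c2cc(/C=C/C(=O)c3cc(OC)c(OC)c(OC)c3)nc3cc(-c4ccccc4)nn23)cc1OC` gives 4700 nM, a gap to compound 3 that lies beyond the scatter. Within the data shown here, compound 1 and compound 3 differ in more than one place, so their two values alone show only that the arrangement in compound 1 sits at a lower number.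

Compound 4 `COc1ccc(-c2cc(/C=C/C(=O)c3ccc(C)cc3)nc3cc(-c4ccccc4)nn23)cc1OC` differs from compound 3 by 2-((4-methylphenyl)carbonyl)ethenyl in place of (2-(4-methylphenyl)ethenyl)carbonyl on an aromatic carbon. Among the measured compounds shown here, the one measured step, a 1.0-fold higher number from compound 2 to compound 3 (0.01 log units; within the scatter), concerns a methyl in place of a methoxy and does not touch the orientation of the enone, so no measured step bears directly on the change here. Compound 1 carries the carbonyl on the aryl side, as compound 4 does, and its lower number suggests this orientation need not cost potency, though compound 1 also carries a different aryl substitution.

For the measured compounds named here, with no direct precedent, a modest step toward a lower number is expected, a 1.9-fold lower number from compound 3 to compound 4 (0.27 log units; within the scatter), wide in its range. Compound 4 is therefore estimated at 12000 nM in this assay, between 4000 nM and 35000 nM.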

Compound 4, half-maximal inhibitory concentration: 19800 nM
For compound 4 the middle estimate is 1.7-fold (0.22 log units) below the measured one, and the stated range covers the measured number.
By their numbers in this assay, from the lowest: compound 1; then compounds 4, 2 and 3 (each within the scatter of the next).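

Reversing the enone on this aromatic carbon gives, in this assay, a 1.1-fold lower number from compound 3 to compound 4 (0.06 log units; within the scatter), so with a 4-methylphenyl group at the end of the chain, the orientation of the enone does not separate the two compounds. Swapping (2-(4-methoxyphenyl)ethenyl)carbonyl for 2-((4-methylphenyl)carbonyl)ethenyl gives a 1.1-fold lower number from compound 2 to compound 4 (0.05 log units; within the scatter), which places all three of these compounds together. The first single-place change beyond the scatter is 4-methylphenyl in place of 3,4,5-trimethoxyphenyl on a carbonyl carbon, with a 4.2-fold higher number from compound 1 to compound 4 (0.62 log units; beyond the scatter), so among the compounds shown the number moves with the aryl group on the carbonyl carbon and not with the enone orientation.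

Still open, as far as these compounds go, is whether 3,4,5-trimethoxyphenyl would hold its lower number with the enone reversed, and whether an aminophenyl group or a benzoic acid on the carbonyl carbon would move the number further in this assay. Nothing given here accounts for the difference between the 3,4,5-trimethoxyphenyl and 4-methylphenyl compounds.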